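Replacing Anilino with Methyl on the Carbonyl Carbon

The source may report more compounds than this note shows. Statements on the series, on what has been measured and on what is new or still open speak of the compounds shown alone.

Compound 2 `CCCCc1ccc(CNC(=O)Nc2ccccc2)c(=O)n1Cc1ccc(-c2ccccc2-c2nn[nH]n2)cc1` stands lowest of the two measured compounds in a functional assay on the whole organism (artery) for inhibition, with Rattus norvegicus as the target, at a dose of 3 mg/kg by the intraduodenal route (a higher number here means more inhibition at the dose given (going by the name of the read-out), a lower number less inhibition), giving 0%. Among the measured compounds shown here, compound 1 `CCCCc1ccc(CN(C(C)C)S(C)(=O)=O)c(=O)n1Cc1ccc(-c2ccccc2-c2nn[nH]n2)cc1` gives 82.7%, and the single measured step, a number 82.7 percentage points lower from compound 1 to compound 2 (beyond the scatter), is the only guide available. Compound 3 `CCCCc1ccc(CNC(C)=O)c(=O)n1Cc1ccc(-c2ccccc2-c2nn[nH]n2)cc1` differs from compound 2 by methyl in place of anilino on a carbonyl carbon. For the measured compounds named here, no measured step touches this carbonyl carbon, so that large step shows only that this region can move the read-out strongly. Compound 3 is expected to rise by a number 20 percentage points higher from compound 2 to compound 3 (beyond the scatter), a modest recovery with wide uncertainty. For compound 3 the estimate is 20%, with a range from 0% to 60%.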

Compound 3, a percentage reported as inhibition, in the whole organism at one dose (the size of the read-out at that dose, not a potency): 8.6%
Compound 3: middle estimate off by 11.4 percentage points, on the high side; low and high end bracket the measured number.
By their numbers in this assay, from the lowest: compounds 2 and 3 (each within the scatter of the next); then compound 1.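

In this assay, the step of a number 8.6 percentage points higher from compound 2 to compound 3 (within the scatter) shows that, on this carbonyl carbon, exchanging anilino for methyl leaves the read-out within the usual scatter. The step of a number 74.1 percentage points lower from compound 1 to compound 3 (beyond the scatter) shows that acetamido, like (phenylcarbamoyl)amino, falls far short of isopropyl(methylsulfonyl)amino on this saturated chain carbon. Nothing available explains these results. The compounds shown leave open whether the isopropyl or the methylsulfonyl part of isopropyl(methylsulfonyl)amino accounts for the difference. They also leave open whether an ethylsulfonyl group or an isopropyl-bearing acetamido nitrogen would restore the inhibition.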